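Swapping Chloro for Trifluoromethyl Before Cathepsin S Testing

The compounds below may be only part of what the source reports. "The series", "measured", "known", "first", "only" and "open" are said of these compounds alone.

In an assay on isolated protein for inhibition of cathepsin S (Homo sapiens), read by fluorescence, with a stated time of 20 min (on this read-out higher numbers stand for weaker inhibition and lower numbers for stronger inhibition), compound 1 `N#CCNC(=O)[C@@H]1CN(S(=O)(=O)c2ccccc2)C[C@H]1C(=O)N1CCOCC1` gives 271 nM.
In this assay compound 2 `N#CCNC(=O)[C@@H]1CN(S(=O)(=O)c2ccccc2Cl)C[C@H]1C(=O)N1CCOCC1` gives 12 nM.

Compound 2 stands lowest of the two numbers. Within the data shown here, the single measured step, a 23-fold lower number from compound 1 to compound 2 (1.35 log units; beyond the scatter), shows that placing chloro on the aromatic carbon sharpened inhibition a great deal. Compound 3 `N#CCNC(=O)[C@@H]1CN(S(=O)(=O)c2ccccc2C(F)(F)F)C[C@H]1C(=O)N1CCOCC1` differs from compound 2 by trifluoromethyl in place of chloro on an aromatic carbon. Among the measured compounds shown here, no measured step covers this exact swap; the one step seen only shows that a group on that aromatic carbon matters. With a group again present there, compound 3 is expected to shift little, a 1.3-fold higher number from compound 2 to compound 3 (0.10 log units; within the scatter), so the estimate for compound 3 is 15 nM, within a range of 4 nM to 60 nM.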

Compound 3, half-maximal inhibitory concentration: 18 nM
Beside the measured number, compound 3's estimate is 1.2-fold (0.08 log units) below it, within the range that was stated.
By their numbers in this assay, from the lowest: compounds 2 and 3 (each within the scatter of the next); then compound 1.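

In this assay the swap reads as a 1.5-fold higher number from compound 2 to compound 3 (0.18 log units; within the scatter) and so trifluoromethyl and chloro cannot be told apart at this aromatic carbon. Against hydrogen the step is a 15-fold lower number from compound 1 to compound 3 (1.18 log units; beyond the scatter) and so the large drop in the number does not depend on chloro alone. No measurement is at hand that explains this result. Going by these compounds, whether fluoro, methoxy or an amine on this same carbon would also give a low number stays open. So does what either group would do on another carbon of this ring.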